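Replacing the (2-hydroxybenzyl)amino group of compound 3

This account rests on a few compounds, and the source may have more. Where it says the series, first, only, none or still open, it means among the compounds named here.

In a functional assay on cells (Homo sapiens) for cytotoxicity, read by MTT assay, with a stated time of 24 h (on this read-out lower numbers stand for stronger inhibition and higher numbers for weaker inhibition), compound 3 `CCCCCCCCCCCCCCNC(=O)[C@H](CO)NCc1ccccc1O` gives 75300 nM, the highest of three numbers. Compound 1 `CCCCCCCCCCCCCCNC(=O)[C@H](CO)/N=C/c1ccc(OC)cc1` gives 28100 nM, and compound 2 `CCCCCCCCCCCCCCNC(=O)[C@H](CO)/N=C/c1ccccc1[N+](=O)[O-]` gives 21700 nM. Compound 4 `CCCCCCCCCCCCCCNC(=O)[C@H](CO)/N=C/c1ccccc1Cl` differs from compound 3 as follows: a group of 9 heavy atoms (7 carbon, 1 nitrogen, 1 chlorine; one six-membered aromatic ring of carbon only) in place of a group of 9 heavy atoms (7 carbon, 1 nitrogen, 1 oxygen; one six-membered aromatic ring of carbon only), on a saturated chain carbon bound to a carbonyl carbon and a saturated chain carbon. The entering group holds a double bond outside aromatic rings, as the matching groups of compound 1 and compound 2 do. The closest guide is a 2.7-fold higher number from compound 1 to compound 3 (0.43 log units; beyond the scatter), a modest step that runs the opposite way. The other guide, a 1.3-fold lower number from compound 1 to compound 2 (0.11 log units; within the scatter), suggests that the aromatic group on such a carbon may matter little, though two compounds are thin evidence. The expected step is a 3.1-fold lower number from compound 3 to compound 4 (0.50 log units; beyond the scatter), towards a lower number. Compound 4 is estimated at 24000 nM, with an expected range of 12000 nM to 48000 nM.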

Compound 4, half-maximal inhibitory concentration: 10300 nM
For compound 4 the middle estimate is 2.3-fold (0.37 log units) above the measured one, and the stated range ends above it.
By their numbers in this assay, from the lowest: compound 4; then compounds 2 and 1 (each within the scatter of the next); then compound 3.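

Among the compounds shown here, exchanging the (2-hydroxybenzyl)amino group for the chlorine-bearing group with its double bond gives a 7.3-fold lower number from compound 3 to compound 4 (0.86 log units; beyond the scatter) as the largest step so far at this position. Among the double-bond compounds, where compound 1 and compound 2 showed no clear difference, the chloro compound now stands apart, with a 2.1-fold lower number from compound 2 to compound 4 (0.32 log units; beyond the scatter) and a 2.7-fold lower number from compound 1 to compound 4 (0.44 log units; beyond the scatter) as steps beyond the scatter. No available evidence explains these steps.

Going by these compounds, the step from compound 3 changes the link and the ring group together, so their separate shares remain unknown. On these data alone, a (2-chlorobenzyl)amino group would separate them, and the effect of a bromo group in place of chloro also remains open.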